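The compounds below may be only part of what the source reports. "The series", "measured", "known", "first", "only" and "open" are said of these compounds alone.

Measured in a functional assay on DU-145 cells (Homo sapiens) for antiproliferative activity, read by sulforhodamine B assay, with a stated time of 72 h; a higher number here means a weaker inhibitor, a lower number a stronger inhibitor:
- compound 1 `Cc1cc(C)nc(NS(=O)(=O)c2ccc(Nc3nncc4ccccc34)cc2)n1`: 7.8 nM
- compound 2 `Fc1ccc(Nc2nncc3ccccc23)cc1`: 4.3 nM
- compound 3 `NS(=O)(=O)c1ccc(Nc2nncc3ccccc23)cc1`: 14 nM

Compound 3 stands within the scatter of compound 1 and apart from compound 2 only. Compound 4 `N#Cc1ccc(Nc2nncc3ccccc23)cc1` has cyano in place of sulfamoyl on an aromatic carbon, para to a large group (cyano in place of sulfamoyl on an aromatic carbon).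

The closest evidence is a change on the same aromatic carbon: a 3.3-fold higher number from compound 2 to compound 3 (0.51 log units; beyond the scatter). The other step, a 1.8-fold higher number from compound 1 to compound 3 (0.25 log units; within the scatter), leaves sulfamoyl's carbon attachment untouched and bears only weakly. Going by the values given here, no cyano compound has been measured, so the direction rests on compound 2 alone. A modest move towards a lower number is expected.

The estimated step in this assay is a 1.8-fold lower number from compound 3 to compound 4 (0.24 log units; within the scatter). Compound 4 is expected at 8 nM, with an estimated range of 3 nM to 20 nM.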

Compound 4, half-maximal inhibitory concentration: 2.1 nM
Beside the measured number, compound 4's estimate is 3.8-fold (0.58 log units) above it, and the stated range ends above it.
By their numbers in this assay, from the lowest: compound 4; then compounds 2, 1 and 3 (each within the scatter of the next, the first and the last beyond it).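

In this assay cyano on this aromatic carbon, para to a large group, gives a lower number than sulfamoyl (a 6.7-fold lower number from compound 3 to compound 4 (0.82 log units; beyond the scatter)) and also a lower number than fluoro (a 2.0-fold lower number from compound 2 to compound 4 (0.31 log units; beyond the scatter)). The earlier compounds shown here compared only sulfamoyl and fluoro on this carbon; three groups now stand in order there, each step beyond the scatter, and fluoro no longer gives the lowest number. Nothing measured here bears on why cyano gives the lowest number on this carbon.

Still open, as far as these compounds go, is where an amine, a carboxylic acid or a methoxy group on this carbon would fall in that order.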